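Swapping the ester acyl group: compound 3 to compound 4

A few compounds are considered here, and "the series" means these few. Any claim that something is new, unique, unknown or untested is made for them only; others in the source may bear on it.

Measured so far in an ADME assay on HepG2 2.2.15 cells (Homo sapiens) for cytotoxicity; a lower number here means that less compound is tolerated, a higher number that more compound is tolerated:
compound 1, `CC(=O)OCCc1c(-c2ccccc2Cl)c2cc(Cl)ccc2[nH]c1=O`, gives 27000 nM;
compound 2, `CC(=O)NCC(=O)OCCc1c(-c2ccccc2Cl)c2cc(Cl)ccc2[nH]c1=O`, gives 110000 nM;
compound 3, `O=C(CCOc1ccccc1)OCCc1c(-c2ccccc2Cl)c2cc(Cl)ccc2[nH]c1=O`, gives 46000 nM.

Compound 3 stands second highest of the three numbers. Its nearest neighbour is compound 1, reached by the step of a 1.7-fold higher number from compound 1 to compound 3 (0.23 log units; within the scatter); its furthest is compound 2, reached by the step of a 2.4-fold lower number from compound 2 to compound 3 (0.38 log units; beyond the scatter). The third measured step, a 4.1-fold higher number from compound 1 to compound 2 (0.61 log units; beyond the scatter), shows that the acetamido group is the only change among these three that moved the number beyond the scatter.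

Compound 4, `C/C=C/C=C/C(=O)OCCc1c(-c2ccccc2Cl)c2cc(Cl)ccc2[nH]c1=O`, is not yet measured. Its difference from compound 3 is penta-1,3-dien-1-yl in place of 2-phenoxyethyl on a carbonyl carbon. Both measured steps that end at compound 3 alter this same ester-side group, and both were at most modest, one within the scatter and one just beyond it. Among the measured compounds shown here, the entering penta-1,3-dien-1-yl group carries no hydrogen-bond acceptor, unlike the acetamido group that produced the one larger step; the data hold no step for a group of this kind. Compound 4 is therefore expected to sit close to compound 3, with a step of a 1.3-fold lower number from compound 3 to compound 4 (0.12 log units; within the scatter) in this assay that stays within or near the scatter. The estimate for compound 4 is 35000 nM, with a range from 15000 nM to 90000 nM.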

Compound 4, half-maximal cytotoxic concentration: 440000 nM
Compound 4: the middle estimate sits 13-fold (1.10 log units) below what was measured; the measured number lies above the stated range.
By their numbers in this assay, from the lowest: compounds 1 and 3 (each within the scatter of the next); then compound 2; then compound 4.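

In this assay this position, the carbonyl carbon whose other neighbour is oxygen next to a carbonyl group, proves far more sensitive than the first three compounds suggested: penta-1,3-dien-1-yl in place of 2-phenoxyethyl gives a 9.6-fold higher number from compound 3 to compound 4 (0.98 log units; beyond the scatter), while the same group gives a 4.0-fold higher number from compound 2 to compound 4 (0.60 log units; beyond the scatter) in place of acetamidomethyl and a 16-fold higher number from compound 1 to compound 4 (1.21 log units; beyond the scatter) in place of methyl. Compound 4 therefore has the highest number of the four, with its steps to all the others beyond the scatter. Its acyl group carries no ring and no hydrogen-bond acceptor, so among these compounds neither feature is needed for more compound to be tolerated, and nothing shown gives a reason for this rise.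

The compounds shown leave open whether the two double bonds matter or only the open carbon chain, a question that a saturated pentyl chain on the same carbonyl carbon would address. They also leave open how an acyl group ending in an amine or a carboxylic acid would behave, and whether the high number would survive an amide in place of the ester.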